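The source may report more compounds than this note shows. Statements on the series, on what has been measured and on what is new or still open speak of the compounds shown alone.

Compound 1 `O=C(CN(c1nc(Cl)nc2[nH]cnc12)C1CC1)N[C@@H](CC(=O)OCc1ccccc1)C(=O)OCc1ccccc1` and compound 2 `CCOC(=O)CN(c1nc(Cl)nc2c1ncn2C1CCCCO1)C1CC1` share the same core, an aminocyclopropyl group and a chloro-substituted heterocycle, and differ in the ester-bearing side chain. In a functional assay on the whole organism (Tail, strain ICR) with Mus musculus as the target, in the tail flick test, with a stated time of 90 min, at a dose of 25 umol/kg by the oral route (on this read-out lower numbers stand for a weaker effect and higher numbers for a stronger effect at the one dose given), compound 1 gives 15.6%, and in this assay compound 2 gives 13%. Within the data shown here, of these two numbers the one for compound 1 is the top one, but the gap to compound 2 lies within the usual scatter of the measurement, so the two compounds cannot be told apart on this read-out; both show only a weak effect at the dose given.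

Compound 3 `CC(C)C[C@H](NC(=O)CN(c1nc(Cl)nc2[nH]cnc12)C1CC1)C(=O)OCc1ccccc1` keeps the core and the cyclopropyl-bearing side of compound 1 unchanged and changes the amino acid ester on the other side: isopropyl in place of benzyloxycarbonyl on a saturated chain carbon, two bonds along the chain from an amide-type nitrogen and a carbonyl carbon. Nothing measured here follows a change of this kind, so no step can be read off for it. Given that both measured compounds sit low in this assay, the change from compound 1 to compound 3 is expected to move the number by no more than the scatter, a number 2.4 percentage points higher from compound 1 to compound 3 (within the scatter), in either direction. Compound 3 is therefore expected to give about 18%, with a likely range from 5% to 40%.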

Compound 3, a percentage reported as activity, at one dose (the size of the read-out at that dose, not a potency): 15.2%
Compound 3: the middle estimate sits 2.8 percentage points above what was measured; the measured number falls inside the stated range.
By their numbers in this assay, from the lowest: compounds 2, 3 and 1 (each within the scatter of the next).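

The read-out of this assay shows a number 0.4 percentage points lower from compound 1 to compound 3 (within the scatter) when isopropyl stands in place of benzyloxycarbonyl on a saturated chain carbon, two bonds along the chain from an amide-type nitrogen and a carbonyl carbon. Among these compounds, this is the first view of a change at this position, and the two groups are very unlike: benzyloxycarbonyl has 10 heavy atoms, an aromatic ring and 2 hydrogen-bond acceptors, while isopropyl has 3 heavy atoms, no ring and no acceptors, yet this read-out cannot tell compound 1 and compound 3 apart at the one dose given. Nothing at hand explains why the two compounds read alike.

Whether an amine or a longer chain at this position would lift the effect clear of the scatter remains open, since isopropyl is the only replacement shown here. As far as these compounds go, compound 1 and compound 3 also both keep a benzyl ester on the carbonyl of the amino acid, so the effect of a free carboxylic acid in its place is unknown too.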